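Swapping a methoxyphenyl for a trifluoromethylphenyl on an adenosine-like core

The source may report more compounds than this note shows. Statements on the series, on what has been measured and on what is new or still open speak of the compounds shown alone.

Compound 1 `COc1cccc(CNc2ncnc3c2ncn3[C@@H]2O[C@H](CO)[C@@H](O)[C@H]2O)c1` has no number of its own in a functional assay on G-361 cells (Homo sapiens) for antiproliferative activity, with a stated time of 72 h; a lower number here means a stronger inhibitor, a higher number a weaker inhibitor: its entry reads "not determined" (no result reported). Among the measured compounds shown here, a related compound 2 `OC[C@H]1O[C@@H](n2cnc3c(NCc4ccccc4C(F)(F)F)ncnc32)C(O)C1O` appears only as a limit of this assay, > 166000 nM, which is the one further value shown, (the limit of > 166000 nM in this assay, at which 1 of the 2 values shown sits). Compound 3 `OC[C@H]1O[C@@H](n2cnc3c(NCc4ccc(C(F)(F)F)cc4)ncnc32)[C@H](O)[C@@H]1O` differs from compound 1 by 4-(trifluoromethyl)phenyl in place of 3-methoxyphenyl on a saturated chain carbon bound to a nitrogen on an aromatic ring. For the measured compounds named here, with no measured step to rest on, any change in this assay from compound 1 to compound 3 cannot be sized, so none beyond the usual scatter is assumed. For compound 3 the estimated result in this assay is 100000 nM, with a range from 20000 nM to 300000 nM.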

Compound 3, half-maximal inhibitory concentration: > 166000 nM
Compound 3: a limit, no number; the forecaster's own chance of this, stated with the estimate: 60%; at least 1.6-fold (0.22 log units) between middle value and limit.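

In this assay compound 3 gives > 166000 nM, which is a limit and not a number. Among the compounds shown here, no step from compound 1 to compound 3 can be read from it. The compounds shown leave open whether swapping 3-methoxyphenyl for 4-(trifluoromethyl)phenyl changes activity at all: the limit of > 166000 nM in this assay, at which 2 of the 3 values shown sit.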